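The source may report more compounds than this note shows. Statements on the series, on what has been measured and on what is new or still open speak of the compounds shown alone.

Compound 2 `C=CCc1cc(C(C)=O)c(O)cc1OCCCCCC` stands lowest of the two numbers in an assay on isolated protein for binding affinity to leukotriene B4 receptor 1 (Homo sapiens), tested at 1 uM (on this read-out lower numbers stand for less inhibition and higher numbers for more inhibition at the one concentration tested (going by the name of the read-out)), where compound 2 gives 9%, while compound 1 `C=CCc1cc(C(C)=O)c(O)cc1OCCCCCCC#N` gives 63%. Going by the values given here, the only measured step, a number 54 percentage points lower from compound 1 to compound 2 (beyond the scatter), concerns removal of cyano and bears on compound 3 `C=CCc1cc(C(C)=O)c(O)cc1OCCCCCCC` only loosely, since compound 3 differs from compound 2 by methyl in place of hydrogen on a saturated chain carbon, six bonds along the chain from an oxygen on an aromatic ring. Nothing measured shows what methyl in place of hydrogen on a saturated chain carbon does here, so the expected change in this assay is none beyond the scatter. Compound 3 is estimated at 12%, within 0% to 30%. This amounts to an expected a number 3 percentage points higher from compound 2 to compound 3 (within the scatter).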

Compound 3, a percentage reported as inhibition, at one concentration (the size of the read-out at that concentration, not a potency): 8%
Beside the measured number, compound 3's estimate is 4 percentage points above it; low and high end bracket the measured number.
By their numbers in this assay, from the lowest: compounds 3 and 2 (each within the scatter of the next); then compound 1.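

In this assay, methyl in place of hydrogen on a saturated chain carbon gives a number 1 percentage points lower from compound 2 to compound 3 (within the scatter), so this added carbon leaves the plain chain without a readable change. Methyl in place of cyano at the same place gives a number 55 percentage points lower from compound 1 to compound 3 (beyond the scatter), so across these three compounds the large separation goes with the cyano end, and matching the chain extension without cyano does not restore the read-out of compound 1. No supporting measurement explains this difference. Open, on these data alone, is whether a carboxylic acid, an amide or an amine at the chain end would match cyano. Also open, as far as these compounds go, is how a shorter or longer chain carrying cyano would read.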